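This account rests on a few compounds, and the source may have more. Where it says the series, first, only, none or still open, it means among the compounds named here.

Going by the values given here, in a functional assay on T47D cells (Homo sapiens) for inhibition, read by CCK-8 assay, with a stated time of 72 h, tested at 1 uM (on this read-out higher numbers stand for more inhibition of growth at the one concentration tested and lower numbers for less inhibition of growth), compound 1 (`CN(C)C(=O)c1cc2cnc(Nc3ccc(NC(=O)C4(C(=O)Nc5ccc(Cl)cc5)CC4)cc3)nc2n1C1CCCC1`) gives 22.8%, the lowest of the three numbers measured so far. Compound 2 (`CN(C)C(=O)c1cc2cnc(Nc3ccc(NC(=O)C4(C(=O)Nc5cccc(O)c5)CC4)cc3)nc2n1C1CCCC1`) gives 80.7%, and compound 3 (`CN(C)C(=O)c1cc2cnc(Nc3ccc(NC(=O)C4(C(=O)Nc5ccccc5F)CC4)cc3)nc2n1C1CCCC1`) gives 85.2%. The gap between these two, a number 4.5 percentage points higher from compound 2 to compound 3 (within the scatter), lies within the scatter.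

Compound 4 (`CN(C)C(=O)c1cc2cnc(Nc3ccc(NC(=O)C4(C(=O)Nc5ccc(Cl)c(C(F)(F)F)c5)CC4)cc3)nc2n1C1CCCC1`) has not yet been measured. It keeps the chloro group of compound 1 and changes 4-chlorophenyl to 4-chloro-3-(trifluoromethyl)phenyl, with trifluoromethyl in place of hydrogen on an aromatic carbon.

Among the compounds with values here, two measured steps bear on this change: a number 57.9 percentage points higher from compound 1 to compound 2 (beyond the scatter) and a number 62.4 percentage points higher from compound 1 to compound 3 (beyond the scatter). Both are large and beyond the scatter, but each replaces the 4-chlorophenyl entirely, whereas compound 4 retains it. Within the data shown here, no measured compound carries a trifluoromethyl, so these steps show how far the number can move with a change in this group, but they do not give the direction for this addition. The estimated step is a number 7.2 percentage points higher from compound 1 to compound 4 (within the scatter), small beside those two. Compound 4 is expected to give 30%, within an estimated range of 10% to 65%.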

Compound 4, percent growth inhibition at one concentration: 6.9%
The estimate for compound 4 lay 23.1 percentage points above the measured number; measured number outside the range, below it.
By their numbers in this assay, from the lowest: compound 4; then compound 1; then compounds 2 and 3 (each within the scatter of the next).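

In this assay, adding trifluoromethyl on the aromatic carbon ortho to a chloro group moves the number down rather than up, with a number 15.9 percentage points lower from compound 1 to compound 4 (beyond the scatter), so this position of the 4-chlorophenyl can still change the read-out even from an already low number. The 4-chloro-3-(trifluoromethyl)phenyl also falls far short of the two aryl groups without chloro, with a number 78.3 percentage points lower from compound 3 to compound 4 (beyond the scatter) and a number 73.8 percentage points lower from compound 2 to compound 4 (beyond the scatter), and among the compounds shown, compound 1 and compound 4, the two that carry chloro, give the two lowest numbers. Nothing measured here explains the drop at this position.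

The compounds shown leave open whether trifluoromethyl on this carbon would lower the number without the chloro group present. They also leave open whether a methyl or an amine at the same place would move it the same way.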